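The compounds below may be only part of what the source reports. "The series", "measured", "known", "first", "only" and "open" are said of these compounds alone.

Among the measured compounds shown here, compound 3 `CCCOCc1cc(O)c(O)c(Br)c1Br` is the one member of this small brominated catechol set for which a number exists: in a functional assay on HCT-116 cells (Homo sapiens) for cytotoxicity, read by MTT assay, with a stated time of 96 h (on this read-out lower numbers stand for stronger inhibition and higher numbers for weaker inhibition), compound 3 gives 1320 nM. Its neighbours are without a result, since compound 1 `OCc1cc(O)c(O)c(Br)c1` shows "not determined" (no result reported) and compound 2 `O=Cc1cc(O)c(O)c(Br)c1Br` shows "not determined" (no result reported) in this assay. Compound 4 `OCc1cc(O)c(O)c(Br)c1Br` is the untested partner of compound 3, and the change between them is hydrogen in place of propyl on an oxygen on a saturated carbon. For the measured compounds named here, no measured pair makes the same move, so nothing here sets its size. With the propyl gone, the expected step in this assay from compound 3 to compound 4 is a 2.3-fold higher number from compound 3 to compound 4 (0.36 log units; beyond the scatter), toward weaker inhibition and only modestly beyond the scatter. Compound 4 is therefore estimated at 3000 nM, within a range of 900 nM to 10000 nM.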

Compound 4, half-maximal inhibitory concentration: 20400 nM
Beside the measured number, compound 4's estimate is 6.8-fold (0.83 log units) below it; measured number above the stated range.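

In this assay this position now has its first measured step, a 15-fold higher number from compound 3 to compound 4 (1.19 log units; beyond the scatter), and it is a large one toward weaker inhibition. The change from propoxymethyl to hydroxymethyl therefore matters on this read-out, and the propyl on this oxygen goes with the stronger inhibition of the pair. The data shown offer no explanation for the size of this step.

Going by these compounds, whether a longer chain, an ethyl group or a methyl group on the same oxygen would match compound 3 stays open. So does whether an amine in place of this oxygen would retain its inhibition.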